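From 2-cyanocyclopropyl to 1-cyanocyclopropyl: a permeability estimate

The compounds below may be only part of what the source reports. "The series", "measured", "known", "first", "only" and "open" are said of these compounds alone.

Measured in an ADME assay on MDCKII-LE cells (Canis lupus familiaris) for permeability; a lower number here means that the compound crosses the layer more slowly, a higher number that the compound crosses the layer faster:
- compound 1 `N#Cc1ccc(CN([C@H](CCC(F)(F)F)C(N)=O)S(=O)(=O)c2ccc(Cl)cc2)cc1`: 19.7 10^-6 cm/s
- compound 2 `N#CCCCN([C@H](CCC(F)(F)F)C(N)=O)S(=O)(=O)c1ccc(Cl)cc1`: 27.6 10^-6 cm/s
- compound 3 `N#C[C@H]1C[C@@H]1CN([C@H](CCC(F)(F)F)C(N)=O)S(=O)(=O)c1ccc(Cl)cc1`: 21.5 10^-6 cm/s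

Compound 3, at 21.5 10^-6 cm/s, lies within the scatter of both other compounds, as the two steps that reach it show: a 1.1-fold higher number from compound 1 to compound 3 (0.04 log units; within the scatter), and a 1.3-fold lower number from compound 2 to compound 3 (0.11 log units; within the scatter). The next compound, compound 4 `N#CC1(CN([C@H](CCC(F)(F)F)C(N)=O)S(=O)(=O)c2ccc(Cl)cc2)CC1`, has 1-cyanocyclopropyl in place of 2-cyanocyclopropyl on a saturated chain carbon bound to a sulfonamide nitrogen. The two have the same atoms, joined differently. Going by the values given here, no measured compound carries 1-cyanocyclopropyl, so the nearest guide is the wider swaps at this same place. Even the change of 4-cyanophenyl to 2-cyanoethyl gave only a 1.4-fold higher number from compound 1 to compound 2 (0.15 log units; within the scatter). All three measured steps stay within the scatter, and none goes against this, so no shift beyond the scatter is expected in this assay. The expected change is a 1.1-fold higher number from compound 3 to compound 4 (0.03 log units; within the scatter). For compound 4 the estimated value is 23 10^-6 cm/s, with an expected range of 13 10^-6 cm/s to 38 10^-6 cm/s.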

Compound 4, apparent permeability: 29.9 10^-6 cm/s
The estimate for compound 4 lay 1.3-fold (0.11 log units) below the measured number, and the stated range covers the measured number.
By their numbers in this assay, from the lowest: compounds 1, 3, 2 and 4 (each within the scatter of the next).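

In this assay, replacing 2-cyanocyclopropyl with 1-cyanocyclopropyl on a saturated chain carbon bound to a sulfonamide nitrogen gives a 1.4-fold higher number from compound 3 to compound 4 (0.14 log units; within the scatter) and shows that rejoining the same atoms, not only exchanging one group for another, leaves the number within the scatter. The two wider comparisons, a 1.1-fold higher number from compound 2 to compound 4 (0.03 log units; within the scatter) and a 1.5-fold higher number from compound 1 to compound 4 (0.18 log units; within the scatter), extend this, so all four nitrile-bearing groups at this position now give values within the scatter of one another. Nothing available here speaks to a cause for these numbers.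

From the compounds shown here alone, all four compounds carry a nitrile, so it remains open whether the number would stay in this range if an amine or a carboxylic acid stood in its place. The same question applies to a plain alkyl chain with no nitrile at its end.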